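Swapping the amide cap of compound 1 for a nitrofuran

The compounds below may be only part of what the source reports. "The series", "measured", "known", "first", "only" and "open" are said of these compounds alone.

Compound 1 `COc1ncc(-c2ccc3ncnc(N[C@H]4CCCN(C(=O)C5CCNCC5)C4)c3c2)cc1C#N` is the weakest of the three measured compounds in a functional assay on SU-DHL-6 cells (Homo sapiens) for antiproliferative activity, read by MTT assay (a higher number here means a weaker inhibitor, a lower number a stronger inhibitor), where compound 1 gives 2440 nM. Compound 2 `COc1ncc(-c2ccc3ncnc(N[C@H]4CCCN(C(=O)CN(C)C)C4)c3c2)cc1C#N` gives 160 nM and compound 3 `COc1ncc(-c2ccc3ncnc(N[C@H]4CCCN(C(=O)c5cccnc5)C4)c3c2)cc1C#N` gives 120 nM. Each change on the carbonyl carbon has helped: a 15-fold lower number from compound 1 to compound 2 (1.18 log units; beyond the scatter) and a 20-fold lower number from compound 1 to compound 3 (1.31 log units; beyond the scatter), while a 1.3-fold lower number from compound 2 to compound 3 (0.12 log units; within the scatter). Compound 4 `COc1ncc(-c2ccc3ncnc(N[C@H]4CCCN(C(=O)c5coc([N+](=O)[O-])c5)C4)c3c2)cc1C#N` carries a further change at the same place: 5-nitrofuran-3-yl in place of piperidin-4-yl on a carbonyl carbon. Both earlier steps away from piperidin-4-yl were large and in the same direction, so a large drop is expected here too, with a 15-fold lower number from compound 1 to compound 4 (1.18 log units; beyond the scatter). Compound 4 is thus estimated at 160 nM, within a range of 50 nM to 600 nM.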

Compound 4, half-maximal inhibitory concentration: 140 nM
For compound 4 the middle estimate is 1.1-fold (0.06 log units) above the measured one; the measured number falls inside the stated range.
By their numbers in this assay, from the lowest: compounds 3, 4 and 2 (each within the scatter of the next); then compound 1.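

Placing 5-nitrofuran-3-yl on the carbonyl carbon in this assay gives a large gain over piperidin-4-yl (a 17-fold lower number from compound 1 to compound 4 (1.24 log units; beyond the scatter)), so a third, quite different cap also avoids the high number of compound 1. The five-membered aromatic ring stands level with both other caps (a 1.2-fold higher number from compound 3 to compound 4 (0.07 log units; within the scatter); a 1.1-fold lower number from compound 2 to compound 4 (0.06 log units; within the scatter)), which shows that this position tolerates varied caps, with compound 1 the one exception. No measurement shown explains why compound 1 stands apart. Going by these compounds, whether the piperidin-4-yl ring itself or its ring nitrogen sets compound 1 apart stays open; a cyclohexyl cap, with carbon in place of that nitrogen, would separate the two.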